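Moving the hydroxyl on the pendant phenyl ring

A few compounds are considered here, and "the series" means these few. Any claim that something is new, unique, unknown or untested is made for them only; others in the source may bear on it.

Measured so far:
compound 1 `Oc1ccc(-c2cc(-c3ccc(Cl)cc3)nc(-c3cccs3)c2)cc1` 6470 nM
compound 2 `Oc1cccc(-c2cc(-c3ccc(Cl)cc3)nc(-c3cccnc3)c2)c1` 16800 nM
compound 3 `Oc1cccc(-c2cc(-c3ccc(Cl)cc3)nc(-c3ccco3)c2)c1` 10200 nM

For the measured compounds named here, in a functional assay on HCT-15 cells (Homo sapiens) for cytotoxicity, read by CCK-8 assay and cell counting, with a stated time of 2 days (on this read-out lower numbers stand for stronger inhibition and higher numbers for weaker inhibition), compound 3 stands second highest of the three numbers, within the scatter of both compound 1 and compound 2; the only measured step, a 1.6-fold lower number from compound 2 to compound 3 (0.22 log units; within the scatter), is itself within the scatter. Compound 4 `Oc1ccc(-c2cc(-c3ccc(Cl)cc3)nc(-c3ccco3)c2)cc1` differs from compound 3 by 4-hydroxyphenyl in place of 3-hydroxyphenyl on an aromatic carbon. Going by the values given here, no measured step bears on this change directly: compound 1 also carries 4-hydroxyphenyl but differs from compound 3 in a second place, so its value and that of compound 3 can only be compared as two numbers within the scatter. The expected step is therefore a 1.3-fold lower number from compound 3 to compound 4 (0.11 log units; within the scatter), none beyond the scatter. Compound 4 is thus estimated at 8000 nM in this assay, within 4000 nM to 16000 nM.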

Compound 4, half-maximal inhibitory concentration: 7020 nM
For compound 4 the middle estimate is 1.1-fold (0.06 log units) above the measured one, and the stated range covers the measured number.
By their numbers in this assay, from the lowest: compounds 1, 4, 3 and 2 (each within the scatter of the next, the first and the last beyond it).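

In this assay, the change from 3-hydroxyphenyl to 4-hydroxyphenyl opposite the ring nitrogen can now be read on its own (a 1.5-fold lower number from compound 3 to compound 4 (0.16 log units; within the scatter)), and the two placements of the hydroxyl are not told apart. Compound 4 also allows furan-2-yl to be compared with thiophen-2-yl on the 4-hydroxyphenyl compounds (a 1.1-fold higher number from compound 1 to compound 4 (0.04 log units; within the scatter)), and these two groups are not told apart either. Nothing available accounts for these readings. The compounds shown leave open whether an amine or a carboxylic acid in place of the hydroxyl would shift the number beyond the scatter.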